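Bromo for ethynyl on two fused bicyclic cores

A few compounds are considered here, and "the series" means these few. Any claim that something is new, unique, unknown or untested is made for them only; others in the source may bear on it.

Measured in a functional assay on NCI-H522 cells (Homo sapiens) for cytotoxicity, with a stated time of 3 days; a lower number here means a stronger inhibitor, a higher number a weaker inhibitor:
compound 1, `C#Cc1nc2ccccc2[se]1`: 2170 nM
compound 2, `Brc1nc2ccccc2[se]1`: a limit only, > 40000 nM
compound 3, `C#Cc1nc2ccccc2n1C`: 8140 nM

Compound 2 sits at the limit of > 40000 nM in this assay, at which 1 of the 3 values shown sits, so its value is a limit of this assay and not a number. The step of an at least 18-fold higher number from compound 1 to compound 2 (1.26 log units; beyond the scatter) is bromo in place of ethynyl on an aromatic carbon. Compound 4, `Cn1c(Br)nc2ccccc21`, is not yet measured; it is the same kind of change made on the core of compound 3, (bromo in place of ethynyl on an aromatic carbon), with the place differing in that here the carbon lies between two ring nitrogen atoms and next to the ring atom that bears a methyl group, whereas in compound 1 it lies next to the ring nitrogen and next to the ring selenium. The difference between the two cores is not broken down here. Compound 3 already gives the higher of the two numbers shown. A step of similar size to the one seen before is expected, an 11-fold higher number from compound 3 to compound 4 (1.04 log units; beyond the scatter), resting on compound 1 to compound 2 giving an at least 18-fold higher number from compound 1 to compound 2 (1.26 log units; beyond the scatter). Compound 4 is therefore expected near 90000 nM, between 25000 nM and 400000 nM, most likely reported only as a limit in this assay.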

Compound 4, half-maximal inhibitory concentration: > 40000 nM
Compound 4 gave a limit, no number; the forecaster's own chance of this, stated with the estimate: 75%; the middle value lies beyond the limit too.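

On the core of compound 3, bromo in place of ethynyl on an aromatic carbon moves the number in this assay in the same direction as on the core of compound 1: an at least 4.9-fold higher number from compound 3 to compound 4 (0.69 log units; beyond the scatter). Compound 4 gives > 40000 nM, which is a limit of the assay and not a number, and it is the same limit reached on the other core: the limit of > 40000 nM in this assay, at which 2 of the 4 values shown sit. The direction of the change therefore carries across the two cores, but its size on each core cannot be compared: the same change on two cores in this assay, an at least 18-fold higher number (1.26 log units; beyond the scatter) from compound 1 to compound 2 and an at least 4.9-fold higher number (0.69 log units; beyond the scatter) from compound 3 to compound 4; the limit leaves it open whether they differ.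

Open, as far as these compounds go, is how other groups on this aromatic carbon, such as an amine, a nitrile or a carboxylic acid, would compare with ethynyl. Also open, from the compounds shown here alone, is how far the two bromo compounds lie from their ethynyl partners in this assay.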